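The source may report more compounds than this note shows. Statements on the series, on what has been measured and on what is new or still open speak of the compounds shown alone.

Measured so far: compound 1 `C=C1CC[C@@H]2[C@](C)(CO)[C@H](O)CC[C@@]2(C)[C@@H]1CCC1=CCOC1=O` with 21000 nM in a functional assay on RAW264.7 cells (Mus musculus) for inhibition, read by Griess assay, with a stated time of 24 h; on this read-out lower numbers stand for stronger inhibition and higher numbers for weaker inhibition. Compound 2 `C=C1CC[C@@H]2[C@](C)(COC3O[C@H](CO)[C@@H](O)[C@H](O)[C@H]3O)CCC[C@@]2(C)[C@@H]1CCC1=CCOC1=O` has also been measured; for it this assay gives only a limit.

Compound 2 stands at the limit of this assay, where it gives > 100000 nM; that is a boundary of the measurement and not a number. The picture is summarised by the limit of > 100000 nM in this assay, at which 1 of the 2 values shown sits, so of compound 2 one can only say that any inhibition it has lies beyond the reach of this assay.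

Compound 3 `C=C1CC[C@@H]2[C@](C)(CO)CCC[C@@]2(C)[C@@H]1CCC1=CCOC1=O` has not been measured. It differs from compound 2 in one place: hydrogen in place of 3,4,5-trihydroxy-6-(hydroxymethyl)oxan-2-yl on an oxygen on a saturated carbon. Compound 3 thus carries the same core with the hydroxymethyl left free. Compound 1, which also carries a free hydroxymethyl and a free oxygen on the ring, gives 21000 nM in this assay, and its value is the nearest guide to what compound 3 may do.

The expected step is therefore a gain in inhibition from compound 2 to compound 3, estimated as an at least 4.0-fold lower number from compound 2 to compound 3 (0.60 log units; beyond the scatter). For compound 3 the estimated value is 25000 nM, expected to fall between 8000 nM and 80000 nM.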

Compound 3, half-maximal inhibitory concentration: 11600 nM
Compound 3: the middle estimate sits 2.2-fold (0.33 log units) above what was measured, within the range that was stated.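

In this assay, going by these compounds alone, hydrogen in place of 3,4,5-trihydroxy-6-(hydroxymethyl)oxan-2-yl on an oxygen on a saturated carbon gives an at least 8.6-fold lower number from compound 2 to compound 3 (0.93 log units; beyond the scatter), which gives the first measured evidence that inhibition can be read once this oxygen is free. The full size of the step cannot be read because compound 2 stands at a limit of the assay, not at a number: the limit of > 100000 nM in this assay, at which 1 of the 3 values shown sits. Hydrogen in place of hydroxy on a saturated ring carbon gives a 1.8-fold lower number from compound 1 to compound 3 (0.26 log units; within the scatter), so the two values cannot be told apart and this ring hydroxy is not needed for the inhibition seen in these two compounds.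

The compounds shown span only the two extremes on the oxygen, the free form and the large oxane-bearing group, so it remains open whether a small group such as methyl or acetyl there would keep the inhibition of the free form. As far as these compounds go, it also remains open how an amine or a carboxylic acid in place of the hydroxymethyl would read in this assay.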